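The compounds below may be only part of what the source reports. "The series", "measured", "known", "first", "only" and "open" are said of these compounds alone.

Compound 1 `Fc1ccccc1CSc1nnc(-c2cnccn2)o1` and compound 2 `Clc1ccccc1CSc1nnc(-c2cnccn2)o1` share one core; compound 3 `Fc1ccccc1CSc1nnc(-c2cnccn2)s1` and compound 4 `Clc1ccccc1CSc1nnc(-c2cnccn2)s1` share another, and the difference between the two cores is not broken down here. In a functional assay on HeLa cells (Homo sapiens) for antiproliferative activity, read by MTT assay, with a stated time of 48 h (a higher number here means a weaker inhibitor, a lower number a stronger inhibitor), compound 1 gives 25300 nM, compound 2 gives 23000 nM and compound 3 gives 32700 nM. The change chloro in place of fluoro on an aromatic carbon made a step of a 1.1-fold lower number from compound 1 to compound 2 (0.04 log units; within the scatter). The same change, (chloro in place of fluoro on an aromatic carbon), links compound 3 to compound 4, at the same place in both pairs. Compound 4 has not been measured. In this assay the step is expected to be about a 1.1-fold lower number from compound 3 to compound 4 (0.04 log units; within the scatter), resting on the earlier step of a 1.1-fold lower number from compound 1 to compound 2 (0.04 log units; within the scatter), which lay within the scatter. Compound 4 is estimated at 30000 nM, with an expected range from 15000 nM to 60000 nM.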

Compound 4, half-maximal inhibitory concentration: 28900 nM
Beside the measured number, compound 4's estimate is 1.0-fold (0.02 log units) above it; the measured number falls inside the stated range.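

In this assay the new step is a 1.1-fold lower number from compound 3 to compound 4 (0.05 log units; within the scatter), and it stands with the earlier step on the other core: the same change on two cores in this assay, a 1.1-fold lower number (0.04 log units; within the scatter) from compound 1 to compound 2 and a 1.1-fold lower number (0.05 log units; within the scatter) from compound 3 to compound 4, 1.0-fold (0.01 log units) apart, within the scatter of two such steps. Chloro in place of fluoro on an aromatic carbon therefore gives no readable difference between the core of compound 1 and the core of compound 3. Within the data shown here, both steps lie within the scatter, so the agreement shows only that this change has no measurable effect on either core, not that a change with a real effect would carry from one core to the other.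

Still open, on these data alone, is whether other groups at this place, such as methoxy, a nitrile or an amine, would give a step beyond the scatter on either core, and whether such a step would match across the two.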